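The source may hold more compounds than are shown below. What is called first, only, known or untested is meant among the compounds shown, and "the series" means these compounds.

Measured compounds:
compound 1 `Cc1cc(C(=O)NCN2CCC(c3cccc[n+]3[O-])CC2)ccc1F`: 50 nM
compound 2 `O=C(CN1CCC(c2cccc[n+]2[O-])CC1)Nc1ccc(F)cc1F`: 103 nM
compound 3 `COc1cccc(C)c1NC(=O)CN1CCC(c2ccccn2)CC1`: 40 nM

All three were tested in a functional assay on HEK293 cells for agonist activity at D(4) dopamine receptor (Homo sapiens), read by FLIPR; a lower number here means that less compound is needed, a higher number that more compound is needed for the effect. Among them compound 1 gives the second highest of the three numbers. Compound 3 stands nearest to it, with a lower number that remains within the scatter, so the two cannot be told apart on these data. Compound 2 stands furthest, its higher number lying beyond the scatter.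

Compound 4 `Cc1cc(C(=O)NCN2CCC(c3cccc[n+]3[O-])CC2)ccc1Cl` has not yet been measured. It differs from compound 1 in one place: chloro in place of fluoro on an aromatic carbon. Going by the values given here, no pair of measured compounds shows a step of this kind, so there is no direct precedent among the three. Exchanging one halogen for another at this place is expected to leave the number close to where compound 1 stands, with any step staying within the scatter. In this assay compound 4 is therefore expected to give 45 nM, with a range from 20 nM to 110 nM. The expected step is a 1.1-fold lower number from compound 1 to compound 4 (0.05 log units; within the scatter).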

Compound 4, half-maximal effective concentration: 2460 nM
Beside the measured number, compound 4's estimate is 55-fold (1.74 log units) below it; the whole stated range lies below it.
By their numbers in this assay, from the lowest: compounds 3 and 1 (each within the scatter of the next); then compound 2; then compound 4.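

In this assay, chloro in place of fluoro on the aromatic carbon gives a 49-fold higher number from compound 1 to compound 4 (1.69 log units; beyond the scatter), so this position does not treat the two halogens alike. The earlier compounds shown here held no step at this place, and this one shows that the change from 4-fluoro-3-methylphenyl to 4-chloro-3-methylphenyl can move the number far beyond the scatter, even though a single heavy atom is exchanged and no hydrogen-bond donor, acceptor or net charge enters or leaves. Nothing at hand on these compounds accounts for the size of this step.

Going by these compounds, what a bromo group or a plain hydrogen would give at this place stays open. On these data alone, it is also open whether a step of this size would recur without the methyl group on the ring, or on another part of the shared core.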